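The source may report more compounds than this note shows. Statements on the series, on what has been measured and on what is new or still open speak of the compounds shown alone.

Working notes on the chalcone series.

For the measured compounds named here, compound 1 `O=C(/C=C/c1ccccc1Cl)c1ccc(OCc2ccccc2)cc1` and compound 2 `O=C(/C=C/c1cccc([N+](=O)[O-])c1)c1ccccc1` are the two measured members. In a functional assay on HCT-116 cells (Homo sapiens) for antiproliferative activity, read by sulforhodamine B assay, with a stated time of 3 days, tested at 50 uM (on this read-out lower numbers stand for a weaker effect and higher numbers for a stronger effect at the one concentration tested), compound 1 gives 99.7%. Compound 2 in this assay gives 99.7%. Compound 1 thus stands level with compound 2 at the digits recorded; the two values lie within the scatter of each other, so no order between them can be stated. Both sit close to full inhibition at the single concentration tested, which leaves little room above them.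

The next member is compound 3 `COc1cccc(/C=C/C(=O)c2ccc(OCc3ccccc3)cc2)c1`. It differs from compound 1 in one place: 3-methoxyphenyl in place of 2-chlorophenyl on a double-bonded chain carbon bound to a double-bonded chain carbon. The benzyloxy-bearing part of compound 1 is kept; the change is confined to the 3-methoxyphenyl entering where the 2-chlorophenyl sat.

Both measured compounds give near-complete inhibition, so the expected step in this assay from compound 1 to compound 3 is a number 5.7 percentage points lower from compound 1 to compound 3 (within the scatter), that is none beyond the scatter or at most a small loss, since a gain is not possible at this level. Compound 3 is therefore estimated at 94%, with a range from 80% to 100% in this assay.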

Compound 3, a percentage reported as inhibition, at one concentration (the size of the read-out at that concentration, not a potency): 76%
The estimate for compound 3 lay 18 percentage points above the measured number, outside the stated range (below it).
By their numbers in this assay, from the lowest: compound 3; then compounds 1 and 2 (each within the scatter of the next).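

In this assay, the group on a double-bonded chain carbon bound to a double-bonded chain carbon is not freely interchangeable: with the benzyloxy-bearing part kept, 3-methoxyphenyl in place of 2-chlorophenyl gives a number 23.7 percentage points lower from compound 1 to compound 3 (beyond the scatter), which also shows that this read-out has room to separate members of the series at the one concentration tested. This single pair joins two changes, the substituent itself and its number on the phenyl ring, and it cannot separate them. Nothing at hand explains the loss.

As far as these compounds go, whether the loss extends to other groups at this place, such as a phenyl ring carrying an amine or a carboxylic acid, remains open, as does whether it would carry over to a core without the benzyloxy-bearing part. From the compounds shown here alone, with compound 1 so close to full inhibition and only one concentration tested, the read-out gives no potency, so the real difference in potency behind this step also remains open.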